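A few compounds are considered here, and "the series" means these few. Any claim that something is new, unique, unknown or untested is made for them only; others in the source may bear on it.

Measured compounds:
- Compound 1, `COc1cc(C2Oc3cc(-c4oc5cc(O)cc(O)c5c(=O)c4OC)ccc3OC2CO)ccc1O`: 11300 nM
- Compound 2, `COc1cc(O)c2c(=O)c(OC)c(-c3ccc4c(c3)OC(c3ccc(O)c(OC)c3)C(CO)O4)oc2c1`: 49900 nM
- Compound 3, `COCC1Oc2ccc(-c3oc4cc(OC)cc(O)c4c(=O)c3O)cc2OC1c1ccc(O)c(OC)c1`: 7300 nM

All three were tested in a functional assay on HUVEC cells (Homo sapiens) for inhibition, read by microscopy and crystal violet staining, with a stated time of 20 h; on this read-out higher numbers stand for weaker inhibition and lower numbers for stronger inhibition. Compound 2 gives the highest number of the three, and the step of a 4.4-fold lower number from compound 2 to compound 1 (0.65 log units; beyond the scatter) is made by a single change: hydrogen in place of methyl on an oxygen on an aromatic ring. Compound 3 gives a number close to that of compound 1; the two lie within the usual scatter of each other, so no order can be read between them, while compound 2 stands clearly apart from both. Compound 3 and compound 2 are built from the same atoms joined differently, and the difference between their two cores is not broken down here.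

Compound 4, `COCC1Oc2ccc(-c3oc4cc(O)cc(O)c4c(=O)c3O)cc2OC1c1ccc(O)c(OC)c1`, has not yet been measured. It is related to compound 3 by hydrogen in place of methyl on an oxygen on an aromatic ring. Among the measured compounds shown here, this is the same kind of change as the one that separates compound 2 from compound 1, and it sits in the same kind of place, on an oxygen on an aromatic ring whose other neighbours are aromatic carbon, but it is now made on the core of compound 3 rather than on that of compound 2. Whether a change carries over from one core to another is not shown by these three compounds alone, so the earlier step is the only guide.

The step from compound 3 to compound 4 is estimated at a 2.9-fold lower number from compound 3 to compound 4 (0.47 log units; beyond the scatter) because a 4.4-fold lower number from compound 2 to compound 1 (0.65 log units; beyond the scatter) points the same way on the other core, with some allowance for the different core. Compound 4 is therefore expected to give 2500 nM in this assay, with a likely range from 800 nM to 7500 nM.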

Compound 4, half-maximal inhibitory concentration: 10500 nM
Beside the measured number, compound 4's estimate is 4.2-fold (0.62 log units) below it; measured number above the stated range.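

In this assay, the change from methoxy to hydroxy on the core of compound 3 gives a 1.4-fold higher number from compound 3 to compound 4 (0.16 log units; within the scatter), so no order can be read between these two compounds. Set beside the earlier step, the same change does not behave alike on the two cores: the same change on two cores in this assay, a 4.4-fold lower number (0.65 log units; beyond the scatter) from compound 2 to compound 1 and a 1.4-fold higher number (0.16 log units; within the scatter) from compound 3 to compound 4, 6.4-fold (0.80 log units) apart, beyond the scatter of two such steps This shows that, within these four compounds, the size of the step on one core is no safe guide to the step on the other, although two pairs cannot explain why they part ways or give a rule for any further core.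

The compounds shown carry only a methoxy or a hydroxy group at the oxygen that changes, so it remains open how an ethoxy group, a longer chain on that oxygen, or an amine in place of the oxygen would read in this assay. As far as these compounds go, it also remains open whether the same change on a third core would give a clear step, as it does between compound 2 and compound 1, or a step within the scatter, as it does between compound 3 and compound 4.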